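Fluoro to Methyl on the Aromatic Ring of Compound 3

This account rests on a few compounds, and the source may have more. Where it says the series, first, only, none or still open, it means among the compounds named here.

Compound 3 `CC1=C(/C=C/C(=O)/C=C/c2ccccc2F)C(C)(C)CCC1` gives 15600 nM in a functional assay on IMR-32 cells (Homo sapiens) for cytotoxicity, read by sulforhodamine B assay, with a stated time of 48 h; a lower number here means a stronger inhibitor, a higher number a weaker inhibitor. Among the three measured compounds it stands second highest: compound 2 `CC1=C(/C=C/C(=O)/C=C/c2ccc(C)cc2)C(C)(C)CCC1` gives 19200 nM, and compound 1 `CC1=C(/C=C/C(=O)/C=C/c2ccc(Br)cc2)C(C)(C)CCC1` gives 10400 nM, and both sit within the scatter of compound 3. Compound 4 `CC1=C(/C=C/C(=O)/C=C/c2ccccc2C)C(C)(C)CCC1` differs from compound 3 by methyl in place of fluoro on an aromatic carbon. Within the data shown here, no measured step matches this change exactly; the closest comparisons are a 1.8-fold higher number from compound 1 to compound 2 (0.27 log units; within the scatter), a 1.5-fold higher number from compound 1 to compound 3 (0.18 log units; within the scatter) and a 1.2-fold lower number from compound 2 to compound 3 (0.09 log units; within the scatter), each a change of the aromatic substituent that stayed within the scatter. Because a 1.8-fold higher number from compound 1 to compound 2 (0.27 log units; within the scatter) and a 1.2-fold lower number from compound 2 to compound 3 (0.09 log units; within the scatter) were this small, the step of a 1.0-fold lower number from compound 3 to compound 4 (0.02 log units; within the scatter) is expected to stay within the scatter too. Compound 4 is therefore estimated at 15000 nM, in a range from 7500 nM to 30000 nM.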

Compound 4, half-maximal inhibitory concentration: 63200 nM
The estimate for compound 4 lay 4.2-fold (0.62 log units) below the measured number, outside the stated range (above it).
By their numbers in this assay, from the lowest: compounds 1, 3 and 2 (each within the scatter of the next); then compound 4.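

In this assay, among these compounds, this single-atom exchange on the ring is the first change here to pass the scatter, with methyl in place of fluoro giving a weaker compound (a 4.1-fold higher number from compound 3 to compound 4 (0.61 log units; beyond the scatter)). The 2-methylphenyl group also sets compound 4 apart from the 4-methylphenyl group of compound 2 (a 3.3-fold higher number from compound 2 to compound 4 (0.52 log units; beyond the scatter)) and the 4-bromophenyl group of compound 1 (a 6.1-fold higher number from compound 1 to compound 4 (0.78 log units; beyond the scatter)), so among these compounds the position of methyl matters. No measurement here explains this shift. From the compounds shown here alone, whether chloro, methoxy or an amine at this place would read like fluoro or like methyl remains open.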